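Longer saturated chain at the ester of compound 1

A few compounds are considered here, and "the series" means these few. Any claim that something is new, unique, unknown or untested is made for them only; others in the source may bear on it.

compound 1, `CCCCCCCC/C=C/CCCCCCCC(=O)O[C@H]1[C@H](O)[C@H](n2ccc(N)nc2=O)O[C@@H]1CO`: 0.05 ug/mL
compound 2, `CCCCCCCCCC(=O)OC[C@H]1O[C@@H](n2ccc(N)nc2=O)[C@@H](O)[C@@H]1O`: 0.1 ug/mL
compound 3, `CCCCCCCC/C=C\CCCCCCCC(=O)OC[C@H]1O[C@@H](n2ccc(N)nc2=O)[C@@H](O)[C@@H]1OC(=O)CCCCCCC/C=C\CCCCCCCC`: 1.1 ug/mL

These three esters of a shared core were tested in a functional assay on HeLa cells (Homo sapiens) for cytotoxicity, read by cell counting, with a stated time of 48 h; on this read-out higher numbers stand for an effect only at larger amounts of compound and lower numbers for an effect already at smaller amounts. Compound 1 gives the lowest of the three numbers. Compound 2 lies nearest to it, within the usual scatter of repeated measurements, so the two cannot be placed in order. Compound 3, which carries two acyl chains, stands furthest from compound 1, with a gap that lies beyond the scatter.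

Among the compounds with values here, compound 4, `CCCCCCCCCCCCCCCCCCCC(=O)O[C@H]1[C@H](O)[C@H](n2ccc(N)nc2=O)O[C@@H]1CO`, keeps the core and the single ester of compound 1 and differs only in the chain: a group of 12 heavy atoms (12 carbon; no ring) in place of a group of 10 heavy atoms (10 carbon; no ring), on a saturated chain carbon, seven bonds along the chain from a carbonyl carbon. Within the data shown here, no pair among the measured compounds differs in just this way, so the size of the step has to be judged from the structural change alone. Since the ester sits on the same carbon and only the group of 12 carbon atoms stands in place of the group of 10 carbon atoms, the expected step, a 2.0-fold higher number from compound 1 to compound 4 (0.30 log units; within the scatter), is small, toward a somewhat higher number, and may well lie within the scatter. For compound 4 in this assay the expected value is 0.1 ug/mL, within a range from 0.03 ug/mL to 0.4 ug/mL.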

Compound 4, concentration for half-maximal effect: 0.1 ug/mL
Estimate against measurement, compound 4: no gap at the digits printed, within the range that was stated.
By their numbers in this assay, from the lowest: compounds 1, 2 and 4 (each within the scatter of the next); then compound 3.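

In this assay, the dodecyl group stands in place of the group of 10 carbon atoms with its one double bond, on a saturated chain carbon, seven bonds along the chain from a carbonyl carbon, and this gives a 2.0-fold higher number from compound 1 to compound 4 (0.30 log units; within the scatter). Within the data shown here, this is the first comparison that isolates a change in one place, which the earlier compounds could not offer, and it shows that this exchange of chains does not separate compound 4 from compound 1 beyond the usual scatter. Nothing on hand accounts for this result.

The exchange adds carbon atoms and removes the double bond in a single step, so the compounds shown cannot tell whether either change alone would leave the number just as close, or whether the two effects offset each other. As far as these compounds go, it also remains open how the number would respond at this position to a much longer chain, a much shorter chain, or a carboxylic acid or an amine in place of the dodecyl group.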